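The source may report more compounds than this note shows. Statements on the series, on what has been measured and on what is new or still open speak of the compounds shown alone.

Measured so far:
compound 1, `Cc1nn(C)c(-n2cccc2)c1/C=N/OCc1ccc(C(=O)OC(C)(C)C)cc1`: 3.91 ug/mL
compound 2, `Cc1nn(C)c(-n2ccc3ccccc32)c1/C=N/OCc1ccc(C(=O)OC(C)(C)C)cc1`: 2.07 ug/mL

Both numbers come from a functional assay on SK-OV-3 cells (Homo sapiens) for cytotoxicity; a higher number here means a weaker inhibitor, a lower number a stronger inhibitor. Compound 1 stands at one end of the two numbers shown, the other belonging to compound 2; the step of a 1.9-fold lower number from compound 1 to compound 2 (0.28 log units; within the scatter) lies within the scatter, so the two compounds cannot be told apart on these data.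

Compound 3 `Cc1nn(C)c(Sc2ccccc2)c1/C=N/OCc1ccc(C(=O)OC(C)(C)C)cc1` is not yet measured. Its difference from compound 1: phenylsulfanyl in place of 1H-pyrrol-1-yl on an aromatic carbon. Among the measured compounds shown here, no measured pair shows this change. For the measured compounds named here, the only measured step at this place, a 1.9-fold lower number from compound 1 to compound 2 (0.28 log units; within the scatter), put 1H-indol-1-yl in place of 1H-pyrrol-1-yl on an aromatic carbon and stayed within the scatter. It bears on compound 3 only loosely, since phenylsulfanyl is neither of those groups. No step beyond the scatter is therefore expected in this assay, in either direction, with a wide range to cover the untested group. Compound 3 is estimated at 3.9 ug/mL, range 1.5 ug/mL to 10 ug/mL, which means an expected step of a 1.0-fold lower number from compound 1 to compound 3 (0.00 log units; within the scatter).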

Compound 3, half-maximal inhibitory concentration: 0.92 ug/mL
Compound 3: middle estimate off by 4.2-fold (0.63 log units), on the high side, outside the stated range (below it).
By their numbers in this assay, from the lowest: compound 3; then compounds 2 and 1 (each within the scatter of the next).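

In this assay, this position on the shared core now gives steps beyond the scatter, both modest, on going to phenylsulfanyl (a 4.3-fold lower number from compound 1 to compound 3 (0.63 log units; beyond the scatter)) and (a 2.3-fold lower number from compound 2 to compound 3 (0.35 log units; beyond the scatter)), whereas 1H-indol-1-yl in place of 1H-pyrrol-1-yl had stayed within it. The number at this place therefore does respond to the group it carries, and among the three compounds, compound 3 alone stands apart from both others, on the lower side. Nothing available accounts for this difference.

Going by these compounds, whether the sulfur atom or the phenyl ring goes with the lower number remains open; phenoxy, anilino or benzyl at the same place would separate the two. Also open, on these data alone, is how a substituted ring, such as 4-chlorophenylsulfanyl, or a simple alkylsulfanyl chain such as methylsulfanyl, would read.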